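A few compounds are considered here, and "the series" means these few. Any claim that something is new, unique, unknown or untested is made for them only; others in the source may bear on it.

Of the compounds shown here, three built on a shared core have been measured in a functional assay on MDA-MB-435 cells (Homo sapiens) for cytotoxicity, read by sulforhodamine B assay, with a stated time of 48 h, tested at 0.1 uM; a higher number here means a weaker effect of the compound at the concentration tested, a lower number a stronger effect. Compound 1 `COc1cc(-c2cc(/C=C/C(=O)c3ccc(N)cc3)[nH]n2)cc(OC)c1OC` gives 95%. Compound 2 `COc1ccc(-c2cc(/C=C/C(=O)c3cc(OC)c(OC)c(OC)c3)[nH]n2)cc1OC` gives 91%, and compound 3 `COc1cc(C(=O)/C=C/c2cc(-c3cc(OC)c(OC)c(OC)c3)n[nH]2)cc(OC)c1OC` gives 94%. Compound 1 therefore stands alongside the other two: its value and those of compound 2 and compound 3 lie within the usual scatter of one another, so none of the three can be set apart on these numbers. Going by the values given here, the only single-site step among them, a number 3 percentage points higher from compound 2 to compound 3 (within the scatter), is a methoxy in place of hydrogen on an aromatic carbon, and it left the read-out where it was.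

Compound 4 `COc1cc(-c2cc(/C=C/C(=O)c3ccc(F)c(F)c3)[nH]n2)cc(OC)c1OC` differs from compound 1 in one place: 3,4-difluorophenyl in place of 4-aminophenyl on a carbonyl carbon. Among the compounds with values here, no measured step touches the same place or the same groups, so nothing among the three compounds speaks for a shift in either direction; what the three values do show is that a change at the edge of this core has so far left this assay nearly flat. On that basis compound 4 is expected to give 93%, with a likely range from 76% to 103%. The step this estimate implies, a number 2 percentage points lower from compound 1 to compound 4 (within the scatter), is expected to stay within the scatter.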

Compound 4, a percentage reported as activity, at one concentration (the size of the read-out at that concentration, not a potency): 90%
Compound 4: the middle estimate sits 3 percentage points above what was measured; the range from low to high includes it.
By their numbers in this assay, from the lowest: compounds 4, 2, 3 and 1 (each within the scatter of the next).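

Going by these compounds alone, replacing 4-aminophenyl with 3,4-difluorophenyl on a carbonyl carbon gives a number 5 percentage points lower from compound 1 to compound 4 (within the scatter) in this assay, the first reading of a change at this place. The exchange takes away the hydrogen-bond donor and acceptor counted on the leaving group and brings in two fluorine atoms, yet the read-out stays within the scatter, so neither group is set apart from the other at this one concentration. Nothing available explains this result.

The compounds shown leave open whether any group on this carbonyl carbon can move the read-out beyond the scatter. From the compounds shown here alone, it also remains open whether a carboxylic acid, a morpholine or an unsubstituted phenyl there would behave as 4-aminophenyl and 3,4-difluorophenyl do.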